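Adding a Trifluoromethyl Group to a Weak Anilide

A few compounds are considered here, and "the series" means these few. Any claim that something is new, unique, unknown or untested is made for them only; others in the source may bear on it.

The two measured compounds share a core in which a hydroxylated benzamide is joined to an aniline. Compound 1, `O=C(Nc1ccc(C(F)(F)F)cc1)c1cc(Br)ccc1O`, carries a bromine on the hydroxylated ring and a trifluoromethyl group on the aniline. In a functional assay on KG-1 cells (Homo sapiens) for cytotoxicity, read by luminescence and CellTiter-Glo, with a stated time of 3 days (a higher number here means a weaker inhibitor, a lower number a stronger inhibitor), compound 1 gives 610 nM. Compound 2, `O=C(Nc1ccccc1)c1cc(F)ccc1O`, carries a fluorine in place of the bromine and a plain aniline. In this assay compound 2 gives > 10000 nM, which is a limit of the assay rather than a number, so compound 2 is only known to be weak, as the limit of > 10000 nM in this assay, at which 1 of the 2 values shown sits, records.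

Compound 3, `O=C(Nc1ccc(C(F)(F)F)cc1)c1cc(F)ccc1O`, keeps the fluorinated core of compound 2 and adds the aniline substituent of compound 1: the change is trifluoromethyl in place of hydrogen on an aromatic carbon. Among the compounds with values here, no measured pair tells how large such a change is here, so the step is uncertain. A gain in potency is expected, an at least 3.3-fold lower number from compound 2 to compound 3 (0.52 log units; beyond the scatter), because compound 1, which carries the same trifluoromethyl group, gives 610 nM. Compound 3 is therefore estimated at 3000 nM, between 800 nM and 10000 nM.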

Compound 3, half-maximal inhibitory concentration: 1700 nM
Beside the measured number, compound 3's estimate is 1.8-fold (0.25 log units) above it, within the range that was stated.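

Compound 3 gives the first measured size for this change. With the fluorinated core held fixed, trifluoromethyl in place of hydrogen on an aromatic carbon, para to a large group, gives an at least 5.8-fold lower number from compound 2 to compound 3 (0.76 log units; beyond the scatter) in this assay, so this substituent alone moves a compound from the weak end of the assay into a measurable range. That step is a floor rather than its full size, since compound 2 stands at a limit of the assay: the limit of > 10000 nM in this assay, at which 1 of the 3 values shown sits. The halogen on the hydroxylated ring also matters, as fluoro in place of bromo on an aromatic carbon gives a 2.8-fold higher number from compound 1 to compound 3 (0.45 log units; beyond the scatter), so the trifluoromethyl group does not set the level of compound 1 by itself.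

As far as these compounds go, it remains open whether other groups at the same place, such as an amine, a carboxylic acid or a longer alkyl chain, would lower the number as well, or whether a chloro group on the hydroxylated ring would fall on the same scale as fluoro and bromo. From the compounds shown here alone, the size of the trifluoromethyl step on the bromo core also remains unknown.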